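Benzotriazine dioxide series: piperidine for dimethylamino

The source may hold more compounds than are shown below. What is called first, only, known or untested is meant among the compounds shown, and "the series" means these compounds.

Measured compounds:
compound 1 `CN(C)CCNc1n[n+]([O-])c2ccccc2[n+]1[O-]` gives 200 nM
compound 2 `[O-][n+]1nc(NCCN2CCCCC2)[n+]([O-])c2ccccc21` gives 1100 nM
compound 3 `CCc1ccc2c(c1)[n+]([O-])c(NCCN(C)C)n[n+]2[O-]` gives 500 nM

All three numbers come from a functional assay on SiHa cells (Homo sapiens) for cytotoxicity, with a stated time of 4 h; on this read-out higher numbers stand for weaker inhibition and lower numbers for stronger inhibition. Compound 1 carries the lowest number of the three. The change from compound 1 to compound 2 is piperidin-1-yl in place of dimethylamino on a saturated chain carbon, two bonds along the chain from a nitrogen on an aromatic ring, and it brings a 5.5-fold higher number from compound 1 to compound 2 (0.74 log units; beyond the scatter). The change from compound 1 to compound 3 is ethyl in place of hydrogen on an aromatic carbon, with a 2.5-fold higher number from compound 1 to compound 3 (0.40 log units; beyond the scatter). The difference between compound 2 and compound 3 is not broken down here; their two values are separated by a gap beyond the scatter, with compound 2 the higher.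

Compound 4 `CCc1ccc2c(c1)[n+]([O-])c(NCCN1CCCCC1)n[n+]2[O-]` has not been measured in this assay. It differs from compound 3 by piperidin-1-yl in place of dimethylamino on a saturated chain carbon, two bonds along the chain from a nitrogen on an aromatic ring. Within the data shown here, this is the same change as the one from compound 1 to compound 2: the groups that leave and enter are the same, and the place is described in the same words. The cores of the two pairs differ by ethyl in place of hydrogen on an aromatic carbon.

Among the measured compounds shown here, two occurrences of the change is a thin basis, but the one measured occurrence is the only guide. The expected step is a 5.0-fold higher number from compound 3 to compound 4 (0.70 log units; beyond the scatter), slightly tempered because a 5.5-fold higher number from compound 1 to compound 2 (0.74 log units; beyond the scatter) need not repeat exactly on the core of compound 3. Compound 4 is therefore estimated at 2500 nM, with a range from 1000 nM to 6000 nM.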

Compound 4, half-maximal inhibitory concentration: 1000 nM
The estimate for compound 4 lay 2.5-fold (0.40 log units) above the measured number, and the stated range covers the measured number.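

In this assay, piperidin-1-yl in place of dimethylamino on the core of compound 3 gives a 2.0-fold higher number from compound 3 to compound 4 (0.30 log units; within the scatter), and ethyl in place of hydrogen on the core of compound 2 gives a 1.1-fold lower number from compound 2 to compound 4 (0.04 log units; within the scatter). The piperidin-1-yl change therefore does not carry over at a constant size from the core of compound 1 to the core of compound 3: the same change on two cores in this assay, a 5.5-fold higher number (0.74 log units; beyond the scatter) from compound 1 to compound 2 and a 2.0-fold higher number (0.30 log units; within the scatter) from compound 3 to compound 4, 2.8-fold (0.44 log units) apart, beyond the scatter of two such steps

The ethyl change shows the same lack of transfer, but the same four compounds are simply being read the other way, so this is one observation rather than two, and it shows neither the cause nor how a further core would respond: the same change on two cores in this assay, a 2.5-fold higher number (0.40 log units; beyond the scatter) from compound 1 to compound 3 and a 1.1-fold lower number (0.04 log units; within the scatter) from compound 2 to compound 4, 2.8-fold (0.44 log units) apart, beyond the scatter of two such steps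

As far as these compounds go, it remains open whether the step for the piperidin-1-yl change would stay small with propyl or methoxy in place of ethyl, or whether it would return to the size seen on the core of compound 1. Also open, from the compounds shown here alone, is how other amines, such as pyrrolidin-1-yl or morpholin-4-yl, or a longer chain carrying the dimethylamino group, would behave on these two cores.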